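Fluoro scan on the hydroxymethylphenyl arm

The source may report more compounds than this note shows. Statements on the series, on what has been measured and on what is new or still open speak of the compounds shown alone.

Measured so far:
compound 1, `Nc1nc(NCCCc2ccccc2)nc(-c2ccccc2CO)n1`: in a functional assay on cells for positive allosteric modulation of G-protein coupled receptor 68 (Homo sapiens), read by a luciferase reporter and cAMP accumulation, with a stated time of 30 min, at pH 6.8 and pH 8.3, in the presence of a further agent that is not named here (on this read-out lower numbers stand for lower potency and higher numbers for higher potency (the scale is a negative logarithm)), compound 1 gives 5.22
compound 2, `Nc1nc(NCCCCc2ccccc2)nc(-c2ccccc2CO)n1`: in this assay compound 2 gives 5.52

The two measured compounds share their core and differ only in the chain carrying the phenyl. The step of a number 0.30 log units higher from compound 1 to compound 2 (within the scatter) lies within the scatter, so compound 2 and compound 1 cannot be told apart on these numbers; compound 2 is simply the measured neighbour of the next compound.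

Compound 3, `Nc1nc(NCCCCc2ccccc2)nc(-c2c(F)cccc2CO)n1`, is not yet measured. It differs from compound 2 by fluoro in place of hydrogen on an aromatic carbon; the chain and the rest of the core are unchanged.

Among the compounds with values here, no measured step touches the hydroxymethylphenyl ring. Within the data shown here, the only step in hand, a number 0.30 log units higher from compound 1 to compound 2 (within the scatter), concerns the chain and is itself within the scatter, so nothing in these data points to a shift in either direction for a fluoro entering at this position. A step of a number 0.02 log units lower from compound 2 to compound 3 (within the scatter) is therefore expected, meaning none beyond the scatter. Among the measured compounds shown here, compound 3 is expected to give 5.5 in this assay, with a range from 4.9 to 6.1, the range left wide for a change with no precedent.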

Compound 3, negative logarithm of the antagonist equilibrium constant: 4.04
For compound 3 the middle estimate is 1.46 log units above the measured one, outside the stated range (below it).
By their numbers in this assay, from the lowest: compound 3; then compounds 1 and 2 (each within the scatter of the next).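

Within the data shown here, the exchange of hydrogen for fluoro gives a number 1.48 log units lower from compound 2 to compound 3 (beyond the scatter) in this assay, the first measured change on the hydroxymethylphenyl ring. This ring carbon, ortho to a large group and meta to a hydroxymethyl group, is therefore sensitive to substitution: the entry of a single heavy atom here moves the number beyond the scatter, whereas the chain change, a number 0.30 log units higher from compound 1 to compound 2 (within the scatter), stays within it. Nothing available bears on the origin of this drop, so the size of the step stands as an observation only.

With fluoro the only substituent shown on this ring, it remains open whether the drop is specific to fluoro or follows from any group on this carbon, a question that a methyl, a chloro or a methoxy group at the same place would address. Also open, going by these compounds, are whether fluoro on the other carbons of this ring gives a step of similar size, and whether the same exchange on the shorter chain of compound 1 does so too.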